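Halogen swap on the arylidene arm of compound 1

The compounds below may be only part of what the source reports. "The series", "measured", "known", "first", "only" and "open" are said of these compounds alone.

Measured compounds:
compound 1 `C=CCn1c(=O)/c(=C\c2cccc(Cl)c2)[nH]c(=O)/c1=C\c1ccccc1OC` – 5500 nM
compound 2 `COc1ccccc1/C=c1/[nH]c(=O)/c(=C\c2ccccc2OC)[nH]c1=O` – "not active" (no number reported), with no number reported

For the measured compounds named here, compound 1 carries the sole numerical reading in a functional assay on HeLa cells (Homo sapiens) for cytotoxicity, read by CCK-8 assay, with a stated time of 72 h (a lower number here means a stronger inhibitor, a higher number a weaker inhibitor), where compound 1 gives 5500 nM; compound 2 is reported only as "not active" (no number reported) and offers no figure to compare against. Compound 3 `C=CCn1c(=O)/c(=C\c2ccccc2F)[nH]c(=O)/c1=C\c1ccccc1OC` differs from compound 1 by 2-fluorophenyl in place of 3-chlorophenyl on a double-bonded chain carbon bound to an aromatic carbon. Going by the values given here, no measured pair shows the effect of such a change here, so the step is expected to stay small, perhaps toward weaker inhibition, or within the scatter. Compound 3 is estimated at 8000 nM, range 3000 nM to 25000 nM, a step of a 1.5-fold higher number from compound 1 to compound 3 (0.16 log units; within the scatter).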

Compound 3, half-maximal inhibitory concentration: 45000 nM
Compound 3: the middle estimate sits 5.6-fold (0.75 log units) below what was measured; the whole stated range lies below it.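

In this assay, for the compounds shown here, the group on the double-bonded chain carbon bound to an aromatic carbon clearly matters: 2-fluorophenyl in place of 3-chlorophenyl gives an 8.2-fold higher number from compound 1 to compound 3 (0.91 log units; beyond the scatter), the first readable step. This single change swaps both the halogen and its place on the phenyl ring, and the pair cannot separate the two. No available data explain the step.

Which of the two differences carries the loss remains open. The response of this position to a phenyl ring bearing an amine or a carboxylic acid is also unknown.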